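A Fluorine Swap on the Benzyl Group

This account rests on a few compounds, and the source may have more. Where it says the series, first, only, none or still open, it means among the compounds named here.

Of the compounds shown here, three have been measured in an assay on isolated protein for inhibition of protein deacetylase HDAC6 (Homo sapiens), read by fluorescence, with a stated time of 1 h, tested at 100 nM; on this read-out lower numbers stand for less inhibition and higher numbers for more inhibition at the one concentration tested (going by the name of the read-out). Compound 1 `O=C(/C=C/c1ccc(OCc2nc(C3CCN(Cc4ccc(F)cc4F)CC3)no2)cc1)NO` gives 74%, compound 2 `CN(Cc1nc(C2CCN(Cc3ccccc3)CC2)no1)c1ncc(/C=C/C(=O)NO)cn1` gives 55%, and compound 3 `CN(Cc1nc(C2CCN(Cc3ccccc3)CC2)no1)c1ncc(C(=O)NO)cn1` gives 63%. Compound 3 stands second highest of the three; the step of a number 8 percentage points higher from compound 2 to compound 3 (within the scatter) lies within the scatter, while compound 1 sits higher by a margin beyond the scatter. Compound 4 `CN(Cc1nc(C2CCN(Cc3ccc(F)cc3)CC2)no1)c1ncc(C(=O)NO)cn1` differs from compound 3 in one place: fluoro in place of hydrogen on an aromatic carbon. Among the compounds with values here, no measured step concerns this kind of change; the one measured step, a number 8 percentage points higher from compound 2 to compound 3 (within the scatter), alters a different part of the molecule, and compound 1 differs from compound 3 in more than one place. With nothing pointing either way, the step of no change at the digits printed from compound 3 to compound 4 (within the scatter) is expected to stay within the scatter. Compound 4 is therefore estimated at 63%, with a range from 50% to 76%.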

Compound 4, a percentage reported as inhibition, at one concentration (the size of the read-out at that concentration, not a potency): 65%
Compound 4: middle estimate off by 2 percentage points, on the low side, and the stated range covers the measured number.
By their numbers in this assay, from the lowest: compounds 2, 3, 4 and 1 (each within the scatter of the next, the first and the last beyond it).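

Going from benzyl to 4-fluorobenzyl gives a number 2 percentage points higher from compound 3 to compound 4 (within the scatter) in this assay. Within the data shown here, this is the first reading of a fluoro at this place on the six-membered aromatic ring, and the read-out does not separate the two compounds at the one concentration tested. No other measurement shown bears on this result.

Open, going by these compounds, is whether a methoxy group or an amine in place of the fluoro would give a number beyond the scatter from compound 3. Also open, on these data alone, is how a fluoro elsewhere on that ring would read.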